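The source may hold more compounds than are shown below. What is called first, only, known or untested is meant among the compounds shown, and "the series" means these compounds.

Working notes on the series. Compound 1 `Cc1cn2c(-c3cn[nH]c3)cnc2c(Nc2cc(Cn3cccc(C)c3=O)ns2)n1` has no number in an ADME assay on the whole organism for pharmacokinetics, with Rattus norvegicus as the target, with a stated time of 6 h, at a dose of 10 mg/kg by the oral route; on this read-out higher numbers stand for higher exposure at the dose given and lower numbers for lower exposure: for compound 1 the entry reads "not determined" (no result reported). Among the compounds with values here, compound 2 `Cc1cn2c(-c3cn[nH]c3)cnc2c(Nc2cc(Cc3ccccn3)ns2)n1` is the only member with a number: in this assay compound 2 gives 6880 ng.h/mL, so within what has been measured compound 2 stands alone and no ranking can be drawn. The next member, compound 3 `Cc1cn2c(-c3cn[nH]c3)cnc2c(Nc2cc(C(NC3CCCC3)c3ccccn3)ns2)n1`, carries cyclopentylamino in place of hydrogen on a saturated chain carbon bound to two aromatic carbons. Within the data shown here, no step between two measured compounds exists in this set, so the size of the move from compound 2 to compound 3 has to be guessed without precedent. The expectation is a moderate loss of exposure, beyond the usual scatter, written as a 2.8-fold lower number from compound 2 to compound 3 (0.44 log units; beyond the scatter). On that basis the exposure of compound 3 in this assay is estimated at 2500 ng.h/mL, with a plausible range from 600 ng.h/mL to 9000 ng.h/mL.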

Compound 3, area under the concentration-time curve: 316 ng.h/mL
The estimate for compound 3 lay 7.9-fold (0.90 log units) above the measured number, outside the stated range (below it).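

Cyclopentylamino in place of hydrogen on a saturated chain carbon bound to two aromatic carbons gives a 22-fold lower number from compound 2 to compound 3 (1.34 log units; beyond the scatter) in this assay and so marks this carbon as a place where exposure responds strongly to substitution. Compound 2 alone gave only a single level of exposure, with nothing to show how far that level depends on what this carbon carries. No measurement at hand bears on the cause of this large step.

A single step cannot separate the contribution of the cyclopentyl ring from that of the amine nitrogen, or from substitution at this carbon as such. From the compounds shown here alone, a methyl group, a hydroxyl group or a dimethylamino group on the same carbon would help to tell these apart, and whether any substituent here can retain the exposure of compound 2 remains open.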